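A Fluoro for Bromo Swap, Measured Once and Expected Again

The source may report more compounds than this note shows. Statements on the series, on what has been measured and on what is new or still open speak of the compounds shown alone.

Of the compounds shown here, three have so far been tested in a functional assay on A549 cells (Homo sapiens) for inhibition, read by sulforhodamine B assay, with a stated time of 48 h; a higher number here means a weaker inhibitor, a lower number a stronger inhibitor. Compound 1 `COC(=O)[C@@]1(C)C[C@@H](c2coc3ccc(Br)cc3c2=O)N(c2ccccc2)O1` gives 9900 nM in this assay. Compound 2 `O=C1[C@H]2[C@H](ON(c3ccccc3)[C@@H]2c2coc3ccc(F)cc3c2=O)C(=O)N1c1ccccc1` gives 13500 nM, and compound 3 `O=C1[C@H]2[C@H](ON(c3ccccc3)[C@@H]2c2coc3ccc(Br)cc3c2=O)C(=O)N1c1ccccc1` gives 17000 nM. All three numbers lie within the scatter of one another, so none of the three can be called a stronger or weaker inhibitor than the others on this evidence.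

Compound 2 and compound 3 share one core and differ in a single place: fluoro in place of bromo on an aromatic carbon. This change produced a 1.3-fold lower number from compound 3 to compound 2 (0.10 log units; within the scatter).

Compound 4 `COC(=O)[C@@]1(C)C[C@@H](c2coc3ccc(F)cc3c2=O)N(c2ccccc2)O1` has not yet been measured. It stands to compound 1 as compound 2 stands to compound 3, since (fluoro in place of bromo on an aromatic carbon). The surroundings of the changed position are described in the same words in both pairs, so the two changes are of the same kind. The cores of compound 1 and compound 3 differ, but that difference is not broken down here.

The expected step from compound 1 to compound 4 is a 1.2-fold lower number from compound 1 to compound 4 (0.09 log units; within the scatter), and this rests on the earlier step because a 1.3-fold lower number from compound 3 to compound 2 (0.10 log units; within the scatter) was seen for the same kind of change. In this assay compound 4 is therefore expected to give about 8000 nM, with the estimate spanning 4000 nM to 16000 nM.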

Compound 4, half-maximal inhibitory concentration: 20300 nM
Compound 4: middle estimate off by 2.5-fold (0.40 log units), on the low side, and the stated range ends below it.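

In this assay, fluoro in place of bromo on an aromatic carbon of the core of compound 1 gave a 2.1-fold higher number from compound 1 to compound 4 (0.31 log units; beyond the scatter), a modest step beyond the scatter, while on the core of compound 3 the same change had given a 1.3-fold lower number from compound 3 to compound 2 (0.10 log units; within the scatter), a step within it. Set side by side, the two steps cannot be told apart: the same change on two cores in this assay, a 1.3-fold lower number (0.10 log units; within the scatter) from compound 3 to compound 2 and a 2.1-fold higher number (0.31 log units; beyond the scatter) from compound 1 to compound 4, 2.6-fold (0.41 log units) apart, within the scatter of two such steps. The series therefore does not show that the core alters the effect of this change, nor does it show that the effect carries over unchanged from one core to the other, and a single pair on each core is too little to settle either point.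

The compounds shown leave open how chloro, iodo or a methoxy group on the same aromatic carbon would compare with bromo and fluoro on either core. They also leave open whether the step seen from bromo to fluoro on the core of compound 1 would hold if a carboxylic acid took the place of the methyl ester there.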